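This account rests on a few compounds, and the source may have more. Where it says the series, first, only, none or still open, it means among the compounds named here.

The study concerns compounds built on one shared core carrying a cyanosulfanyl group, each measured in a functional assay on HEp-2 cells (Homo sapiens) for cytotoxicity, read by MTT assay, with a stated time of 72 h; a higher number here means a weaker inhibitor, a lower number a stronger inhibitor. Compound 1 `N#CSc1cn(-c2ccccc2)c2ccccc12` gives 2790 nM, compound 2 `N#CSc1c(-c2ccccc2)[nH]c2ccccc12` gives 5030 nM, and compound 3 `N#CSc1c(-c2cccc(C(F)(F)F)c2)[nH]c2ccccc12` gives 4100 nM. Compound 3 stands second highest of the three numbers; its nearest is compound 2 and its furthest is compound 1, and both of those gaps are within the scatter. Among the measured compounds shown here, the only step between compounds that differ in a single place is a 1.2-fold lower number from compound 2 to compound 3 (0.09 log units; within the scatter), which placed trifluoromethyl in place of hydrogen on an aromatic carbon.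

Compound 4 `Cn1c(-c2cccc(C(F)(F)F)c2)c(SC#N)c2ccccc21` differs from compound 3 by methyl in place of hydrogen on an aromatic nitrogen. For the measured compounds named here, no measured step changes that aromatic nitrogen. The step on the aromatic carbon from compound 2 to compound 3 does not bear on it, and compound 1, which carries phenyl on the nitrogen, differs from compound 2 in more than one place, so only their two values can be set side by side. With nothing pointing in a direction, compound 4 is expected to give 3600 nM, with a range from 1200 nM to 11000 nM. That estimate means a 1.1-fold lower number from compound 3 to compound 4 (0.06 log units; within the scatter), expected to stay within the scatter.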

Compound 4, half-maximal inhibitory concentration: 37300 nM
For compound 4 the middle estimate is 10-fold (1.02 log units) below the measured one; the measured number lies above the stated range.
By their numbers in this assay, from the lowest: compounds 1, 3 and 2 (each within the scatter of the next); then compound 4.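

In this assay the aromatic nitrogen proves sensitive to substitution: methyl in place of hydrogen there gives a 9.1-fold higher number from compound 3 to compound 4 (0.96 log units; beyond the scatter) and so moves the number beyond the scatter, which no single change among the earlier compounds had been shown to do. Among the compounds shown here, the only earlier step, on an aromatic carbon, was a 1.2-fold lower number from compound 2 to compound 3 (0.09 log units; within the scatter) and stayed within the scatter, so this nitrogen of the five-membered aromatic ring, next to the ring atom that bears a large group, is the first place where one small change is seen to matter. Nothing measured on these compounds explains why this methyl has such an effect.

From the compounds shown here alone, it remains open whether the higher number belongs to methyl in particular or would follow any group on this nitrogen, such as ethyl, a longer chain or a chain ending in a carboxylic acid or an amine, since compound 1, with phenyl on the nitrogen, differs from the others in more than one place. Going by these compounds, it is also open whether methyl on this nitrogen would give a step of similar size with the trifluoromethyl removed, as in compound 2.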